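Chloromethylbenzyl series: testing the second ring chloro

The source may report more compounds than this note shows. Statements on the series, on what has been measured and on what is new or still open speak of the compounds shown alone.

Measured so far:
compound 1 `ClCc1ccc(Cn2cnc3c(Cl)ncnc32)cc1` — 2130 nM
compound 2 `ClCc1ccccc1Cn1cnc2c(Cl)nc(Cl)nc21` — 380 nM

For the measured compounds named here, in a functional assay on RPMI-8226 cells (Homo sapiens) for cytotoxicity, read by sulforhodamine B assay, with a stated time of 48 h (a higher number here means a weaker inhibitor of growth, a lower number a stronger inhibitor of growth), compound 2 gives 380 nM, the lowest of the two numbers so far. Compound 1 gives 2130 nM, and the gap between the two lies beyond the scatter. Compound 1 and compound 2 differ in two places at once, so neither change can be read on its own from these two values.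

Compound 3 `ClCc1ccccc1Cn1cnc2c(Cl)ncnc21` separates one of them from compound 2: hydrogen in place of chloro on an aromatic carbon. Going by the values given here, no single-change step is known, so the size of this step can only be estimated. The expectation is a moderate rise in the number, likely beyond the scatter but smaller than the gap between compound 1 and compound 2, since that gap also contains the shift of the chloromethyl group. For compound 3 the estimate in this assay is 900 nM, with a range from 300 nM to 2700 nM. This estimate corresponds to an expected step of a 2.4-fold higher number from compound 2 to compound 3 (0.37 log units; beyond the scatter).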

Compound 3, concentration for 50% growth inhibition: 14100 nM
Compound 3: the middle estimate sits 16-fold (1.19 log units) below what was measured, outside the stated range (above it).
By their numbers in this assay, from the lowest: compound 2; then compound 1; then compound 3.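

Placing hydrogen on the aromatic carbon between two ring nitrogen atoms gives, in this assay, a 37-fold higher number from compound 2 to compound 3 (1.57 log units; beyond the scatter), so the series is highly sensitive to this one change. For the compounds shown here, this is the first single-change reading, and it shows that the chloro at this position alone accounts for a large effect, which the two-place gap between compound 1 and compound 2 could not show. Nothing available here bears on why this change has so large an effect.

Still open, as far as these compounds go, is whether this position needs chloro specifically, or whether an amine or a methoxy group there would hold the lower number of compound 2. Also open, from the compounds shown here alone, is whether the step keeps its size with the chloromethyl group placed as in compound 1.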